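Amidoxime in place of acetyl on the chromene series

The source may hold more compounds than are shown below. What is called first, only, known or untested is meant among the compounds shown, and "the series" means these compounds.

- compound 1 `CC(=O)c1ccc2c(c1)C(n1ccccc1=O)=CC(C)(C)O2`: 7.37
- compound 2 `CC1(C)C=C(n2ccccc2=O)c2cc(C(=O)c3ccc([N+](=O)[O-])cc3)ccc2O1`: 6.2
- compound 3 `CC1(C)C=C(n2ccccc2=O)c2cc(C(=O)c3ccccc3C(F)(F)F)ccc2O1`: 6.76

All three compounds share one core and differ only in the group on the carbonyl carbon. In a functional assay (aorta) with Rattus norvegicus as the target (on this read-out higher numbers stand for higher potency (the scale is a negative logarithm) and lower numbers for lower potency), compound 1 stands highest of the three numbers; its nearest neighbour is compound 3, and compound 2 is furthest. Both measured steps away from compound 1 go down: a number 1.17 log units lower from compound 1 to compound 2 (beyond the scatter) and a number 0.61 log units lower from compound 1 to compound 3 (beyond the scatter); the step of a number 0.56 log units higher from compound 2 to compound 3 (beyond the scatter) separates the two aryl ketones.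

Compound 4 `CC1(C)C=C(n2ccccc2=O)c2cc(C(=N)NO)ccc2O1` is the untested member. Relative to compound 1 the change is a group of 4 heavy atoms (1 carbon, 2 nitrogen, 1 oxygen; no ring) in place of a group of 3 heavy atoms (2 carbon, 1 oxygen; no ring), on an aromatic carbon. Within the data shown here, no measured step exchanges the acetyl for a group of this kind, so the two steps from compound 1 give only an indirect bearing: every departure from the acetyl measured so far has cost potency, by a modest to large amount. The change to compound 4 is smaller in heavy-atom count than either aryl ketone, so a modest loss is expected rather than a large one, a number 0.77 log units lower from compound 1 to compound 4 (beyond the scatter). For compound 4 the expected value in this assay is 6.6, estimated to fall between 5.8 and 7.4.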

Compound 4, logarithm of the reciprocal of the active concentration, log(1/C): 5.99
Compound 4: middle estimate off by 0.61 log units, on the high side; the measured number falls inside the stated range.
By their numbers in this assay, from the lowest: compounds 4 and 2 (each within the scatter of the next); then compound 3; then compound 1.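

The step of a number 1.38 log units lower from compound 1 to compound 4 (beyond the scatter) shows that a small group without a ring, with 4 heavy atoms, can lose as much at this position as an aryl ketone, so heavy-atom count does not order the series. Compound 4 at 5.99 and compound 2 at 6.2 lie within the scatter of each other, despite the far larger 4-nitrophenyl ketone in compound 2. No available evidence accounts for the loss in compound 4, where the entering group has 3 hydrogen-bond donors and the acetyl has 0.

On these data alone, it remains open whether any other group at this aromatic carbon can match the acetyl, for example a propanoyl, a nitrile or a primary amide. These compounds also cannot separate the effect of the added donors from that of losing the ketone.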